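The source may hold more compounds than are shown below. What is called first, only, known or untested is meant among the compounds shown, and "the series" means these compounds.

In a functional assay on HT-29 cells (Homo sapiens) for inhibition, read by MTT assay, with a stated time of 72 h (a lower number here means a stronger inhibitor, a higher number a weaker inhibitor), three compounds on a shared core have been measured. Compound 1 `C=C(Br)C(=O)Nc1cccc(/C=C/C(=O)Nc2ccc(F)cc2)c1` gives 36600 nM, compound 2 `C=C(Br)C(=O)Nc1cccc(/C=C/C(=O)Nc2ccc(Cl)cc2)c1` gives 7900 nM, and compound 3 `C=C(Br)C(=O)Nc1cccc(/C=C/C(=O)Nc2ccc(OC)cc2)c1` gives 2300 nM, the lowest number of the three. Compound 4 `C=C(Br)C(=O)Nc1cccc(/C=C/C(=O)Nc2ccc(OC)c(OC)c2)c1` differs from compound 3 by methoxy in place of hydrogen on an aromatic carbon, ortho to a methoxy group. Among the compounds with values here, no measured step makes this exact change. The closest evidence is a 4.6-fold lower number from compound 1 to compound 2 (0.67 log units; beyond the scatter), then a 16-fold lower number from compound 1 to compound 3 (1.20 log units; beyond the scatter) and a 3.4-fold lower number from compound 2 to compound 3 (0.54 log units; beyond the scatter), the last two with methoxy replacing a halogen-bearing substituent's fluoro or chloro. They say nothing direct about a second methoxy, so only a small further drop in this assay is expected, perhaps none beyond the scatter. The expected step is a 1.4-fold lower number from compound 3 to compound 4 (0.13 log units; within the scatter). For compound 4 the estimated value is 1700 nM, with an expected range of 600 nM to 5000 nM.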

Compound 4, half-maximal inhibitory concentration: 1900 nM
The estimate for compound 4 lay 1.1-fold (0.05 log units) below the measured number; measured number inside the range.
By their numbers in this assay, from the lowest: compounds 4 and 3 (each within the scatter of the next); then compound 2; then compound 1.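

In this assay adding a methoxy group where a hydrogen stood, ortho to a methoxy group, gives a 1.2-fold lower number from compound 3 to compound 4 (0.08 log units; within the scatter) and so stays within the scatter. The earlier compounds shown here only exchanged one substituent for another, whereas this step shows that the ring accepts a second methoxy at this carbon with no measurable change in this assay. Nothing shown here offers an explanation for this result. The compounds leave open whether an amine, a hydroxyl or a longer chain such as ethoxy at this carbon would read the same. They also leave open how this methoxy would behave without the first one.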